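Removing one chloro from the dichloro analogue compound 2

The compounds below may be only part of what the source reports. "The series", "measured", "known", "first", "only" and "open" are said of these compounds alone.

Compound 2 `ClCc1ccccc1Cn1cnc2c(Cl)nc(Cl)nc21` gives the lowest of the two numbers shown in a functional assay on UACC-257 cells (Homo sapiens) for cytotoxicity, read by sulforhodamine B assay, with a stated time of 48 h (a lower number here means that less compound is tolerated, a higher number that more compound is tolerated), at 8510 nM; compound 1 `ClCc1ccc(Cn2cnc3c(Cl)ncnc32)cc1` gives the higher number of 97700 nM. Compound 3 `ClCc1ccccc1Cn1cnc2c(Cl)ncnc21` differs from compound 2 by hydrogen in place of chloro on an aromatic carbon. Among the compounds with values here, no step between measured compounds is available, so compound 3 is expected to shift moderately upward in this assay, toward more compound being tolerated, by the estimated step of a 2.9-fold higher number from compound 2 to compound 3 (0.47 log units; beyond the scatter). Compound 3 is therefore estimated at 25000 nM, in a range from 8000 nM to 80000 nM.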

Compound 3, concentration lethal to 50% of the cells: 66100 nM
For compound 3 the middle estimate is 2.6-fold (0.42 log units) below the measured one; the measured number falls inside the stated range.
By their numbers in this assay, from the lowest: compound 2; then compounds 3 and 1 (each within the scatter of the next).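

Within the data shown here, compound 2 and compound 3 give the first direct reading of this position: on the aromatic carbon between two ring nitrogen atoms, hydrogen in place of chloro gives a 7.8-fold higher number from compound 2 to compound 3 (0.89 log units; beyond the scatter) in this assay. Without this chloro, compound 3 stands within the scatter of compound 1, so the low number of compound 2 goes with the chloro in this pair. Nothing given here accounts for the step. The compounds shown leave open how an amine, a methoxy group or a methyl group on this carbon would compare with chloro and hydrogen.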